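A few compounds are considered here, and "the series" means these few. Any claim that something is new, unique, unknown or untested is made for them only; others in the source may bear on it.

Two compounds of the series carry a number in a functional assay on HEK293 cells for activation of melanin-concentrating hormone receptor 1 (Rattus norvegicus), read by inositol phosphate accumulation; a higher number here means that more compound is needed for the effect, a lower number that less compound is needed. Compound 1 `CC(C)N(C)c1ccc2cc(NC(=O)CCc3ccc(C(F)(F)F)cc3)ccc2n1` gives 140 nM in this assay, and compound 2 `O=C(CCc1ccc(C(F)(F)F)cc1)Nc1ccc2nc(N3CC4CC3CN4)ccc2c1` gives 490 nM. Going by the values given here, the only step measured so far, a 3.5-fold higher number from compound 1 to compound 2 (0.54 log units; beyond the scatter), exchanges the open-chain tertiary amine of compound 1 for the bridged diamine of compound 2. Compound 2 therefore stands at the higher of the two numbers, and compound 1 is its nearest neighbour.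

Compound 3 `CN(c1ccc2cc(NC(=O)CCc3ccc(C(F)(F)F)cc3)ccc2n1)C1CCCCC1` is the next member. Relative to compound 2 the change is a group of 8 heavy atoms (7 carbon, 1 nitrogen; one six-membered non-aromatic ring of carbon only) in place of a group of 7 heavy atoms (5 carbon, 2 nitrogen; 2 five-membered non-aromatic rings with 1 hetero atom each), on an aromatic carbon. Among the compounds with values here, the one step that bears on this is a 3.5-fold higher number from compound 1 to compound 2 (0.54 log units; beyond the scatter), which ran in the opposite direction when a tertiary amine without a donor was replaced by the diamine; compound 3 returns to a tertiary amine of that kind, differing from compound 1 only by the ring size of the alkyl group. Within the data shown here, a step back of comparable size is expected, that is a 3.3-fold lower number from compound 2 to compound 3 (0.51 log units; beyond the scatter), because a 3.5-fold higher number from compound 1 to compound 2 (0.54 log units; beyond the scatter) is the only precedent. For compound 3 the estimate is 150 nM, expected to fall between 55 nM and 420 nM.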

Compound 3, half-maximal effective concentration: 1200 nM
The estimate for compound 3 lay 8.0-fold (0.90 log units) below the measured number, and the stated range ends below it.
By their numbers in this assay, from the lowest: compound 1; then compound 2; then compound 3.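

Keeping the tertiary amine and changing only the carbon group on its nitrogen, cyclohexyl in place of isopropyl, gives an 8.6-fold higher number from compound 1 to compound 3 (0.93 log units; beyond the scatter) in this assay, so the number at this position, next to the ring nitrogen, responds to that carbon group with no hydrogen-bond donor entering. The other step, a 2.4-fold higher number from compound 2 to compound 3 (0.39 log units; beyond the scatter), runs in the same direction as a 3.5-fold higher number from compound 1 to compound 2 (0.54 log units; beyond the scatter), which places compound 2, with its hydrogen-bond donor, between compound 1 and compound 3, two tertiary amines without one, so the donor count alone does not order these three compounds. Nothing given here explains either step.

As far as these compounds go, with only isopropyl and cyclohexyl on the tertiary amine, it remains open whether the number follows the size of that group, as a methyl, cyclopropyl or cyclopentyl group on the same nitrogen would help to show. From the compounds shown here alone, it also remains open whether the bridged diamine's place in the order belongs to its free ring amine or to its bridged frame, a question that piperazine or morpholine at the same aromatic carbon would bear on.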